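Benzyl to 4-methylpiperidin-1-yl on a chain carbon

A few compounds are considered here, and "the series" means these few. Any claim that something is new, unique, unknown or untested is made for them only; others in the source may bear on it.

In a physicochemical assay for solubility, read by spectrophotometry, in phosphate buffer, with a stated time of 2 h, at pH 7.4 (on this read-out lower numbers stand for lower solubility and higher numbers for higher solubility), compound 2 `COc1ccc2[nH]c(C(=O)N3CC(=O)N(Cc4ccccc4)[C@@H](CCc4ccccc4)C3)cc2c1` gives 4400 nM and compound 1 `COc1cccc(CN2C(=O)CN(C(=O)c3cc4cc(OC)ccc4o3)C[C@@H]2CCc2ccccc2)c1` gives 4900 nM, a pair within the usual scatter. Compound 3 `COc1ccc2[nH]c(C(=O)N3CC(=O)N(Cc4ccccc4)[C@@H](CN4CCC5(CC4)CC5)C3)cc2c1` gives 28200 nM. Compound 4 `COc1ccc2[nH]c(C(=O)N3CC(=O)N(Cc4ccccc4)[C@@H](CN4CCC(C)CC4)C3)cc2c1`, not yet measured, carries 4-methylpiperidin-1-yl in place of benzyl on a saturated chain carbon bound to a saturated ring carbon. Among the compounds with values here, only one measured step bears on this change: a 6.4-fold higher number from compound 2 to compound 3 (0.81 log units; beyond the scatter). That step also puts a non-aromatic ring in place of the aromatic one, at the same place, so this is thin evidence. A similar upward step is expected in this assay, an estimated 5.7-fold higher number from compound 2 to compound 4 (0.75 log units; beyond the scatter). For compound 4 the expected value is 25000 nM, with an estimated range of 11000 nM to 58000 nM.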

Compound 4, solubility: 93100 nM
The estimate for compound 4 lay 3.7-fold (0.57 log units) below the measured number; measured number above the stated range.
By their numbers in this assay, from the lowest: compounds 2 and 1 (each within the scatter of the next); then compound 3; then compound 4.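

In this assay, 4-methylpiperidin-1-yl in place of benzyl on this saturated chain carbon gives a 21-fold higher number from compound 2 to compound 4 (1.33 log units; beyond the scatter), a large step. The two non-aromatic nitrogen-bearing groups are also not interchangeable at this place: changing the group of compound 3 to 4-methylpiperidin-1-yl gives a 3.3-fold higher number from compound 3 to compound 4 (0.52 log units; beyond the scatter), a modest step. No measurement shown here gives a reason for either step. As far as these compounds go, it remains open whether the ring nitrogen or the loss of the aromatic ring matters more; a morpholine or an open-chain dimethylamino group at this place could help separate the two.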